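The source may hold more compounds than are shown below. What is called first, only, known or untested is meant among the compounds shown, and "the series" means these compounds.

Measured so far in a functional assay on Bel-7402 cells (Homo sapiens) for inhibition, read by MTT assay, with a stated time of 24 h, tested at 100 ug/mL; a higher number here means more inhibition of growth at the concentration tested, a lower number less inhibition of growth:
- compound 1 `O=C(CCCCC(S)CCS)Nc1ccccc1` gives 7.67%
- compound 2 `O=C(CCCCC(S)CCS)Nc1ccccc1Cl` gives "not active" (no number reported)
- compound 3 `O=C(CCCCC(S)CCS)Nc1cccc(C(F)(F)F)c1` gives 25.3%

Of the two numbers available, compound 1 holds the lower, with compound 3 as its nearest neighbour. Compound 2 has no number, so no step can be read from it, and it stands as a reminder that a substituted analogue may give no measurable result.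

The next analogue, compound 4 `O=C(CCCCC(S)CCS)Nc1ccc(OC(F)(F)F)cc1`, has not yet been measured. It departs from compound 1 by a single change: trifluoromethoxy in place of hydrogen on an aromatic carbon. Among the measured compounds shown here, one measured step bears on this change. Trifluoromethyl in place of hydrogen on an aromatic carbon gave a number 17.6 percentage points higher from compound 1 to compound 3 (beyond the scatter). That step involves a different group, and it is the only one of its kind, so it carries over only loosely. A rise in the same direction is expected in this assay, probably no larger than that modest step. The expected step is a number 12.3 percentage points higher from compound 1 to compound 4 (beyond the scatter). For compound 4 the estimated value is 20%, with an expected range from 5% to 40%.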

Compound 4, percent growth inhibition at one concentration: 49.7%
For compound 4 the middle estimate is 29.7 percentage points below the measured one; measured number above the stated range.
By their numbers in this assay, from the lowest: compound 1; then compound 3; then compound 4.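

In this assay, trifluoromethoxy in place of hydrogen on an aromatic carbon, para to a large group, gives a number 42 percentage points higher from compound 1 to compound 4 (beyond the scatter), a large step and the first shown at this place on the ring. It establishes that growth inhibition at the tested concentration can rise substantially when the core of compound 1 carries trifluoromethoxy there, whereas the earlier step, a number 17.6 percentage points higher from compound 1 to compound 3 (beyond the scatter), involved a different group and gave no reading of this place. The two steps do not separate the contribution of the group from that of its place, and no measurement shown here explains the result.

As far as these compounds go, it remains open whether trifluoromethoxy itself or simply occupation of this place accounts for the rise, a question that trifluoromethyl at the same place, or trifluoromethoxy elsewhere on the ring, would help to settle. From the compounds shown here alone, it is also open how a methoxy group, an amine or a carboxylic acid at this place would read in this assay, and whether the rise would continue with any of them.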